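One Added Methoxy on Compound 2

The source may hold more compounds than are shown below. What is called first, only, known or untested is meant among the compounds shown, and "the series" means these compounds.

In a functional assay on COLO 205 cells (Homo sapiens) for inhibition, read by sulforhodamine B assay (on this read-out higher numbers stand for weaker inhibition of growth and lower numbers for stronger inhibition of growth), compound 1 (`COc1cc(-c2ccc(-c3ccc(-c4nc5cc(C)ccc5[nH]4)cc3)cc2)cc(OC)c1OC`) gives 190 nM and compound 2 (`COc1ccc(-c2ccc(-c3ccc(-c4nc5c(O)cccc5[nH]4)cc3)cc2)cc1OC`) gives 1320 nM as the higher of the two numbers. Compound 2 therefore stands as the weaker inhibitor of growth of this pair, by a margin beyond the usual scatter.

Compound 3 (`COc1cc(-c2ccc(-c3ccc(-c4nc5c(O)cccc5[nH]4)cc3)cc2)cc(OC)c1OC`) has not yet been measured. It differs from compound 2 by one change, methoxy in place of hydrogen on an aromatic carbon. The new group stands ortho to a methoxy group, meta to a second methoxy group and meta to a large group.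

Among the measured compounds shown here, no two measured compounds differ in one place only, so the size of this step has not been directly observed. For the measured compounds named here, the only lower number available is that of compound 1 at 190 nM and it shows that stronger inhibition is reached in this small set. In this assay a moderate move towards a lower number is therefore expected, and it may only just clear the scatter. The estimated change is a 2.9-fold lower number from compound 2 to compound 3 (0.47 log units; beyond the scatter) and it points towards stronger inhibition of growth. Compound 3 is expected at 450 nM within an estimated range from 150 nM to 1300 nM when measured.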

Compound 3, concentration for 50% growth inhibition: 190 nM
Compound 3: middle estimate off by 2.4-fold (0.37 log units), on the high side; the range from low to high includes it.
By their numbers in this assay, from the lowest: compounds 1 and 3 (each within the scatter of the next); then compound 2.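

In this assay the added methoxy is now an observed step rather than an estimate: the change gives a 6.9-fold lower number from compound 2 to compound 3 (0.84 log units; beyond the scatter) and points towards stronger inhibition of growth. Among the compounds shown here, this places a clear effect on the aromatic carbon that stands ortho to a methoxy group, meta to a second methoxy group and meta to a large group, a position on which the earlier compounds offered no single-change comparison. With this methoxy present, the exchange of 5-methyl-1H-benzimidazol-2-yl for 4-hydroxy-1H-benzimidazol-2-yl gives no change at the digits printed from compound 1 to compound 3 (within the scatter) and so leaves the two compounds indistinguishable in this read-out, while no measurement available here explains either step.

The compounds shown do not reveal whether the methoxy step would be of similar size with 5-methyl-1H-benzimidazol-2-yl in place of 4-hydroxy-1H-benzimidazol-2-yl, since only one pair tests the added methoxy. They also leave open how an ethoxy group, a fluorine atom or an amine on the same aromatic carbon would compare with methoxy or hydrogen, and a single cell line cannot show whether the step carries over to other cells.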